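Adding Bromine to a Compound Without Measurable Cytotoxicity

This account rests on a few compounds, and the source may have more. Where it says the series, first, only, none or still open, it means among the compounds named here.

Compound 1 `O=[N+]([O-])c1cc(CSc2nnc(-c3ccccc3)n2-c2ccc(Cl)c(Cl)c2)cc([N+](=O)[O-])c1` and compound 2 `O=[N+]([O-])c1cc(CSc2nnc(-c3ccccc3)n2Cc2ccccc2)cc([N+](=O)[O-])c1` share one core and differ at a single position. In an ADME assay on A-431 cells (Homo sapiens) for cytotoxicity, with a stated time of 48 h (on this read-out higher numbers stand for weaker inhibition and lower numbers for stronger inhibition), compound 1 gives > 30000 nM, which is a limit of the assay and not a number. In this assay compound 2 gives > 30000 nM, again a limit. The step that the two limits leave unreadable from compound 1 to compound 2 cannot be read because both values sit at the limit of > 30000 nM in this assay, at which 2 of the 2 values shown sit.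

Compound 3 `O=[N+]([O-])c1cc(CSc2nnc(-c3ccc(Br)cc3)n2Cc2ccccc2)cc([N+](=O)[O-])c1` has not been measured yet. It differs from compound 2 by bromo in place of hydrogen on an aromatic carbon, para to a large group. Going by the values given here, no measured step involves this change, and the one measured step is itself unreadable. Compound 2 offers only a limit as the starting point, so the expected step that the limit leaves unreadable from compound 2 to compound 3 is no more than a guess at no change beyond the scatter. Compound 3 is therefore expected at 40000 nM, within 12000 nM to 130000 nM, most likely reported again as a limit.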

Compound 3, half-maximal inhibitory concentration: > 30000 nM
Compound 3: only a limit was reported; the forecaster's own chance of this, stated with the estimate: 85%; the middle value lies beyond the limit too.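

In this assay compound 3 gives > 30000 nM, again a limit and not a number. The step from compound 2 to compound 3 cannot be read because both values sit at the same limit: the limit of > 30000 nM in this assay, at which 3 of the 3 values shown sit.

As far as these compounds go, how much either change affects cytotoxicity in these cells remains open, as compounds 1, 2 and 3 give no measured number.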